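Chloro substitution on the shared core: cytotoxicity notes

A few compounds are considered here, and "the series" means these few. Any claim that something is new, unique, unknown or untested is made for them only; others in the source may bear on it.

compound 1 `O=C(NCCCO)c1cnc2ccccc2c1Cl` — a limit, > 100 uM in an ADME assay on CCRF-CEM cells (Homo sapiens) for cytotoxicity; on this read-out lower numbers stand for higher toxicity in this test and higher numbers for lower toxicity in this test
compound 2 `COC(=O)[C@H](CO)NC(=O)c1cnc2ccccc2c1Cl` — a limit, > 100 uM in this assay

In this assay compound 1 reaches only the assay limit, > 100 uM. Compound 2 likewise gives only a limit, > 100 uM. The step that the two limits leave unreadable from compound 1 to compound 2 is therefore unreadable. Compound 2 stands at the limit of > 100 uM in this assay, at which 2 of the 2 values shown sit. Compound 3 `COC(=O)[C@H](CO)NC(=O)c1cnc2c(Cl)cccc2c1Cl` differs from compound 2 by chloro in place of hydrogen on an aromatic carbon. For the measured compounds named here, no measured step reads on this change. With both measured compounds at the limit, compound 3 is expected to show a step of a number no higher from compound 2 to compound 3 (the limit leaves the size open) and an estimated value of 100 uM (range 30 uM to 300 uM), most probably again reported only as a limit.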

Compound 3, half-maximal toxic concentration: > 100 uM
Compound 3 was reported as a limit (the forecaster's own chance of this, stated with the estimate: 75%); the middle value lies on the limit itself.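

For the compounds shown here, compound 2 and compound 3 both give only a limit in this assay, so no step between them can be read. Left open is whether chloro in place of hydrogen on an aromatic carbon changes toxicity at all.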